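The compounds below may be only part of what the source reports. "The series", "measured", "known", "first", "only" and "open" are said of these compounds alone.

Compound 1 `COCCC1=C(N2CC2)C(=O)C(CCOC)=C(N2CC2)C1=O`: 4.71
Compound 2 `CCC1=C(N2CC2)C(=O)C(C(COC(N)=O)OC)=C(N2CC2)C1=O`: 4.92

In a functional assay on L1210 cells (Mus musculus), with a stated time of 1 days (a lower number here means a less potent compound, a higher number a more potent compound, by a factor of ten per unit of this negative logarithm), compound 1 gives 4.71, and compound 2 gives 4.92, the two numbers lying within the usual scatter of each other, so neither can be set apart from the other. Compound 3 `COCCC1=C(N2CC2)C(=O)C(C)=C(N2CC2)C1=O` has not yet been measured. It differs from compound 1 by hydrogen in place of methoxymethyl on a saturated chain carbon bound to a double-bonded ring carbon. Within the data shown here, no measured pair shows this change, so its effect in this assay is unknown; with the two measured compounds so close together, no step beyond the scatter is expected. Compound 3 is estimated at 4.7, with a range from 4.2 to 5.2. The step is expected to be a number 0.01 log units lower from compound 1 to compound 3 (within the scatter).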

Compound 3, logarithm of the reciprocal of the active concentration, log(1/C): 5.12
Compound 3: the middle estimate sits 0.42 log units below what was measured; measured number inside the range.
By their numbers in this assay, from the lowest: compounds 1, 2 and 3 (each within the scatter of the next, the first and the last beyond it).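

In this assay, among these compounds, hydrogen in place of methoxymethyl on a saturated chain carbon bound to a double-bonded ring carbon gives a number 0.41 log units higher from compound 1 to compound 3 (beyond the scatter) and is the first change here to clear the scatter. At this place on the shared core, the 2-methoxyethyl group is therefore not needed for activity, and methyl gives the more potent compound. Nothing available here accounts for the rise. From the compounds shown here alone, whether an amine, a carboxylic acid or a longer chain at this place would keep the gain remains open. So does whether the same change at the remaining 2-methoxyethyl group would repeat it.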